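This account rests on a few compounds, and the source may have more. Where it says the series, first, only, none or still open, it means among the compounds named here.

Compound 1 `Oc1ccccc1CNc1ccccc1` gives "not active" (no number reported)
Compound 2 `Oc1ccccc1CNc1ccc(-c2ccc(Cl)cc2)cc1` gives 2390 nM

Among the measured compounds shown here, in a functional assay on Jurkat cells (Homo sapiens) for activation, with a stated time of 24 h (a lower number here means that less compound is needed, a higher number that more compound is needed for the effect), compound 2 holds the only number reported, with compound 1 standing as the one further entry without a single number. Compound 3 `Oc1ccccc1CNc1ccc(-c2cccc(Cl)c2)cc1` has not yet been measured in this assay. It differs from compound 2 by 3-chlorophenyl in place of 4-chlorophenyl on an aromatic carbon. For the measured compounds named here, no measured pair shows a step of this kind, so the change is expected to be small, leaning toward a higher number but quite possibly staying within the scatter. Compound 3 is therefore estimated at 3500 nM, with a range from 1000 nM to 12000 nM. This amounts to an expected step of a 1.5-fold higher number from compound 2 to compound 3 (0.17 log units; within the scatter).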

Compound 3, half-maximal effective concentration: 6200 nM
Compound 3: middle estimate off by 1.8-fold (0.25 log units), on the low side; low and high end bracket the measured number.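

In this assay, the 3-chlorophenyl in place of 4-chlorophenyl gives a 2.6-fold higher number from compound 2 to compound 3 (0.41 log units; beyond the scatter) with the same atoms joined differently, so the place of the chlorine on this ring shifts the number modestly but beyond the scatter. Among the compounds shown here, this is the first step at this position, and it shows that the read-out responds to where the chlorine sits, not only to which atoms are present. Nothing measured here accounts for the difference. The compounds shown leave open whether a nitrile, a methoxy group, an amine or a carboxylic acid in place of the chlorine would lower or raise the number. They also leave open whether the same preference would hold for any of these groups.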